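Working notes: from 2,4-dichlorophenyl to 3,4-dichlorophenyl

The compounds below may be only part of what the source reports. "The series", "measured", "known", "first", "only" and "open" are said of these compounds alone.

Values so far in a functional assay on SW-620 cells (Homo sapiens) for cytotoxicity, read by MTT assay, with a stated time of 72 h; a lower number here means a stronger inhibitor, a higher number a weaker inhibitor
- compound 1 `COc1ccc(/C=C2\CCC/C(=C\c3ccc(O)cc3)C2=O)cc1OC` gives 7700 nM
- compound 2 `COc1ccc(/C=C2\CCC/C(=C\c3ccc(Cl)cc3Cl)C2=O)cc1OC` gives 10300 nM

Among the compounds with values here, compound 2 stands within the scatter of compound 1, its only measured neighbour. Compound 3 `COc1ccc(/C=C2\CCC/C(=C\c3ccc(Cl)c(Cl)c3)C2=O)cc1OC` differs from compound 2 as follows (3,4-dichlorophenyl in place of 2,4-dichlorophenyl on a double-bonded chain carbon bound to a double-bonded ring carbon), with 3,4-dichlorophenyl in place of 2,4-dichlorophenyl on a double-bonded chain carbon bound to a double-bonded ring carbon. Within the data shown here, the one measured step at this place (a 1.3-fold higher number from compound 1 to compound 2 (0.13 log units; within the scatter)) stayed within the scatter, and no measured pair compares the two dichlorophenyl groups. No step beyond the scatter is therefore expected in this assay, and the expected step is small (a 1.1-fold lower number from compound 2 to compound 3 (0.06 log units; within the scatter)). Compound 3 is estimated at 9000 nM (range 4500 nM to 18000 nM).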

Compound 3, half-maximal inhibitory concentration: 4000 nM
For compound 3 the middle estimate is 2.3-fold (0.35 log units) above the measured one; measured number below the stated range.
By their numbers in this assay, from the lowest: compounds 3, 1 and 2 (each within the scatter of the next, the first and the last beyond it).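

In this assay, within the data shown here, 3,4-dichlorophenyl and 2,4-dichlorophenyl, with the same atoms joined differently, are not interchangeable on the double-bonded chain carbon (a 2.6-fold lower number from compound 2 to compound 3 (0.41 log units; beyond the scatter)), the first step at this place beyond the scatter. Replacing 4-hydroxyphenyl with 3,4-dichlorophenyl, by contrast, stays within the scatter (a 1.9-fold lower number from compound 1 to compound 3 (0.28 log units; within the scatter)). No measurement available here accounts for the difference between the two dichlorophenyl groups. Still open, on these data alone, is how 4-chlorophenyl or an aminophenyl group would compare at this place. As far as these compounds go, the effect of changing the 3,4-dimethoxyphenyl group on the other side of the shared core also remains open.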